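This account rests on a few compounds, and the source may have more. Where it says the series, first, only, none or still open, it means among the compounds named here.

Measured compounds:
compound 1 `CC(C)OC(=O)N1CCC(Oc2ncnc3c2CCN3c2ccc(S(C)(=O)=O)cc2F)CC1`: 50.1 nM
compound 2 `CCOC(=O)N1CCC(Oc2ncnc3c2CCN3c2ccc(S(C)(=O)=O)cc2F)CC1`: 251 nM

In a functional assay on CHO-K1 cells for agonist activity at Glucose-dependent insulinotropic receptor (Homo sapiens), read by a luciferase reporter, with a stated time of 5 h (on this read-out lower numbers stand for an effect already at smaller amounts and higher numbers for an effect only at larger amounts of compound), compound 1 gives 50.1 nM and compound 2 gives 251 nM. Compound 2 therefore stands at the higher of the two numbers, separated from compound 1 by the step of a 5.0-fold higher number from compound 1 to compound 2 (0.70 log units; beyond the scatter), which lies beyond the scatter. Compound 3 `CCCOC(=O)N1CCC(Oc2ncnc3c2CCN3c2ccc(S(C)(=O)=O)cc2F)CC1` is not yet measured in this assay. It differs from compound 2 by methyl in place of hydrogen on a saturated chain carbon, two bonds along the chain from an oxygen next to a carbonyl group, which reads as ethyl to propyl on the chain carried by the oxygen.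

Going by the values given here, only one measured step bears on this: a 5.0-fold higher number from compound 1 to compound 2 (0.70 log units; beyond the scatter), in which a methyl was removed from the chain carbon bound to the oxygen. The methyl entering in compound 3 sits two bonds further along the chain, a different place, so that step is only a loose guide. A modest move back toward the number of compound 1 is expected, of size a 1.8-fold lower number from compound 2 to compound 3 (0.25 log units; within the scatter). For compound 3 in this assay the estimate is 140 nM, within 50 nM to 400 nM.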

Compound 3, half-maximal effective concentration: 79.4 nM
The estimate for compound 3 lay 1.8-fold (0.25 log units) above the measured number; the range from low to high includes it.
By their numbers in this assay, from the lowest: compounds 1 and 3 (each within the scatter of the next); then compound 2.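

In this assay, the methyl entering two bonds along the chain from an oxygen next to a carbonyl group, which turns ethoxy into propoxy, gives a 3.2-fold lower number from compound 2 to compound 3 (0.50 log units; beyond the scatter). The number on this series therefore responds to a methyl at this outer place on the chain as well as to the one at the chain carbon bound to the oxygen, seen in a 5.0-fold higher number from compound 1 to compound 2 (0.70 log units; beyond the scatter). Swapping the branched chain for the straight one, propyl in place of isopropyl, gives a 1.6-fold higher number from compound 1 to compound 3 (0.20 log units; within the scatter), so these two chains cannot be told apart here, and no measurement on hand accounts for any of these steps.

On these data alone, whether the trend carries on to a longer chain such as butyl remains open. So does the effect of a cyclopropyl group or an amine on the same oxygen.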